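A few compounds are considered here, and "the series" means these few. Any claim that something is new, unique, unknown or untested is made for them only; others in the source may bear on it.

Compound 1 `COc1ccc([C@@H]2CC(=O)c3c(O)cc(OCc4cn(Cc5ccccc5Cl)nn4)cc3O2)cc1O` sets the lowest number of the three measured compounds in a functional assay on RAW264.7 cells (Mus musculus) for inhibition, read by Griess assay, with stated times of 2 h and 24 h (on this read-out higher numbers stand for weaker inhibition and lower numbers for stronger inhibition), where compound 1 gives 6140 nM. Compound 2 `COc1ccc([C@@H]2C/C(=N\O)c3c(O)cc(OCc4cn(Cc5ccccc5Cl)nn4)cc3O2)cc1O` carries an oxime in place of the carbonyl of compound 1; in this assay compound 2 gives a number of 13400 nM. Compound 3 `COc1ccc([C@@H]2CC(=O)c3c(O)cc(OCc4cn(Cc5ccc(C(F)(F)F)cc5)nn4)cc3O2)cc1O` gives in this assay a number of 17700 nM, the highest of the three; its gap to compound 2 lies within the scatter, while its gap to compound 1 is the measured step of a 2.9-fold higher number from compound 1 to compound 3 (0.46 log units; beyond the scatter).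

Compound 4 `CCCCn1cc(COc2cc(O)c3c(c2)O[C@H](c2ccc(OC)c(O)c2)CC3=O)nn1` is not yet measured. It differs from compound 3 by propyl in place of 4-(trifluoromethyl)phenyl on a saturated chain carbon bound to an aromatic nitrogen. Among the measured compounds shown here, the only measured step touching this position is a 2.9-fold higher number from compound 1 to compound 3 (0.46 log units; beyond the scatter), which exchanged one aromatic ring for another; no measured pair exchanges the aromatic ring for a chain, so that step bears on the change only loosely. For the measured compounds named here, because the one relevant step, a 2.9-fold higher number from compound 1 to compound 3 (0.46 log units; beyond the scatter), was modest, and the present change has no direct precedent, a step of no more than modest size in either direction is expected in this assay for compound 4, most likely one within the scatter. The step from compound 3 is expected to be a 1.2-fold lower number from compound 3 to compound 4 (0.07 log units; within the scatter). The number for compound 4 in this assay is therefore estimated at 15000 nM, within a range from 6000 nM to 40000 nM.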

Compound 4, half-maximal inhibitory concentration: 13900 nM
Beside the measured number, compound 4's estimate is 1.1-fold (0.03 log units) above it; measured number inside the range.
By their numbers in this assay, from the lowest: compound 1; then compounds 2, 4 and 3 (each within the scatter of the next).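

In this assay, among the compounds shown here, the position on a saturated chain carbon bound to an aromatic nitrogen now shows an aromatic ring exchanged for a chain for the first time, and with a 1.3-fold lower number from compound 3 to compound 4 (0.10 log units; within the scatter), the two compounds cannot be told apart, so holding this level does not depend on the ring of compound 3. Compound 1 remains separate from both, with a 2.9-fold higher number from compound 1 to compound 3 (0.46 log units; beyond the scatter) and a 2.3-fold higher number from compound 1 to compound 4 (0.35 log units; beyond the scatter), so at this position the 2-chlorophenyl compound stands apart, while the propyl and 4-(trifluoromethyl)phenyl compounds share one level. No evidence is available to explain these results.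

The compounds shown leave open whether the difference seen with compound 1 belongs to the chlorine or to its place on the ring, which a plain phenyl or a 4-chlorophenyl group at this position could help to separate. They also leave open how far a chain can be varied here, as a longer chain such as octyl, or a chain ending in an amine or a carboxylic acid, has no number among them.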